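Aryl swap in a hydroxy-diketone chromone series

The compounds below may be only part of what the source reports. "The series", "measured", "known", "first", "only" and "open" are said of these compounds alone.

Compound 1 `CCCOc1ccc(-c2cc(=O)c3c(o2)C(CC)(CC)C(=O)C(CC)=C3O)cc1` and compound 2 `CCC1=C(O)c2c(oc(-c3ccc(SC)cc3)cc2=O)C(CC)(CC)C1=O` share one core. In a functional assay on KB cells (Homo sapiens) for antiproliferative activity, read by sulforhodamine B assay, with a stated time of 3 days (a lower number here means that less compound is needed, a higher number that more compound is needed for the effect), compound 1 gives > 50.5 uM, which is a limit of the assay. Compound 2 gives > 52.1 uM in this assay, also a limit. The change a step that the two limits leave unreadable from compound 1 to compound 2 is therefore unreadable, so compound 2 stands only at a limit. Compound 3 `CCC1=C(O)c2c(oc(-c3ccccc3F)cc2=O)C(CC)(CC)C1=O` differs from compound 2 by 2-fluorophenyl in place of 4-(methylsulfanyl)phenyl on an aromatic carbon. Among the measured compounds shown here, no measured step reads, and both neighbours sit at limits the limit of > 50.5 uM in this assay, at which 1 of the 2 values shown sits (the limit of > 52.1 uM in this assay, at which 1 of the 2 values shown sits). Compound 3 is thus expected to give 50 uM (range 15 uM to 120 uM). The estimated step of an at least 1.0-fold lower number from compound 2 to compound 3 (0.01 log units; that floor lies within the scatter) is expected to lie within the scatter.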

Compound 3, concentration for half-maximal effect: > 56.2 uM
Compound 3 ended at the assay's limit (the forecaster's own chance of this, stated with the estimate: 75%); middle value at least 1.1-fold (0.05 log units) away from the limit.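

Among the compounds shown here, compound 2 and compound 3 both stand only at limits, so no step between them can be read. The compounds shown leave open what concentration compound 1, compound 2 or compound 3 needs for the effect, and whether changing the aryl group alters it.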